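Swapping Chloro for Trifluoromethyl in a Tolerated Series

The source may hold more compounds than are shown below. What is called first, only, known or untested is meant among the compounds shown, and "the series" means these compounds.

Compound 1 `O=C(Nc1cccc(-n2cc(-c3ccncc3)c(-c3ccc(Cl)c(O)c3)n2)c1)Nc1ccc(Cl)c(Cl)c1` was tested in a functional assay on K562 cells (Homo sapiens) for inhibition, read by sulforhodamine B assay, with a stated time of 48 h; a higher number here means that more compound is tolerated, a lower number that less compound is tolerated. Compound 1 gave only a limit there, > 32500 nM, not a number. Compound 2 `O=C(Nc1cccc(-n2cc(-c3ccncc3)c(-c3ccc(Cl)c(O)c3)n2)c1)Nc1cc(C(F)(F)F)cc(C(F)(F)F)c1` also gave only a limit in this assay, > 50000 nM. Compound 3 `COc1cc(-c2nn(-c3cccc(NC(=O)Nc4cccc(C(F)(F)F)c4)c3)cc2-c2ccncc2)ccc1Cl` likewise reached only a limit in this assay, > 50000 nM. So compound 1 stands at the limit of > 32500 nM in this assay, at which 1 of the 3 values shown sits, while the two other compounds sit at the limit of > 50000 nM in this assay, at which 2 of the 3 values shown sit; since all three results are limits rather than numbers, none of them can be ranked against another. Compound 4 `O=C(Nc1cccc(-n2cc(-c3ccncc3)c(-c3ccc(Cl)c(O)c3)n2)c1)Nc1ccc(Cl)c(C(F)(F)F)c1` has not yet been measured. It differs from compound 1 by trifluoromethyl in place of chloro on an aromatic carbon. Among the compounds with values here, no step between two measured compounds is available to size this change. Because every value shown sits at the limit of > 32500 nM in this assay, at which 1 of the 3 values shown sits, or (the limit of > 50000 nM in this assay, at which 2 of the 3 values shown sit), compound 4 is expected to give a limit in this assay as well. The expected step in this assay, a step that the limit leaves unreadable from compound 1 to compound 4, is none beyond the scatter. Compound 4 is estimated at 50000 nM, between 20000 nM and 120000 nM.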

Compound 4, concentration lethal to 50% of the cells: > 32500 nM
Compound 4: no number, only a limit (the forecaster's own chance of this, stated with the estimate: 85%); the middle value does not contradict the limit.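

Compound 1 and compound 4 each gave only a limit in this assay, not a number, so no step can be read for trifluoromethyl in place of chloro. The compounds shown leave open whether any change to the shared core would give a readable number.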